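From Compound 3 to Compound 4: A Stability Estimate

A few compounds are considered here, and "the series" means these few. Any claim that something is new, unique, unknown or untested is made for them only; others in the source may bear on it.

Of the compounds shown here, three built on a shared core have been measured so far in an ADME assay (liver) for metabolic stability, with Liver microsome (Canis lupus familiaris) as the target, read by LC-MS, using microsomes, with a stated time of 30 min, tested at 4 uM (on this read-out lower numbers stand for a less stable compound and higher numbers for a more stable compound), and their values are spread widely. There, compound 1 `COCCn1c(-c2ccccc2Cl)nc2c(N3CCN(C(C)=O)CC3)nc(C)nc21` shows 34% while compound 3 `COc1ccccc1-c1nc2c(N3CCN(C)CC3)nc(C)nc2n1C1CCOCC1` shows 36% and these two cannot be told apart within the usual scatter. Compound 2 `CCN1CCN(c2nc(C)nc3c2nc(-c2ccccc2Cl)n3CC2CCOCC2)CC1` reaches 76% and stands apart from compound 3 by more than the scatter.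

Compound 4 `COc1ccc(-c2nc3c(N4CCN(C)CC4)nc(C)nc3n2C2CCOCC2)c(C)c1` has not yet been measured. It differs from compound 3 in one place only (4-methoxy-2-methylphenyl in place of 2-methoxyphenyl on an aromatic carbon) with 4-methoxy-2-methylphenyl in place of 2-methoxyphenyl on an aromatic carbon.

Among the measured compounds shown here, no two measured compounds differ in just one place, so the data give no direct measure of what such a swap does. The best starting point is therefore compound 3 at 36% and the spread of the three values calls for a broad range. The estimated step is small and downward, within the scatter (a number 6 percentage points lower from compound 3 to compound 4 (within the scatter)). This slight downward lean is a judgement and not a measured trend. For compound 4 the estimate is 30% with an expected range from 12% to 52% for the measurement still to come.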

Compound 4, percent of the compound remaining: 41%
The estimate for compound 4 lay 11 percentage points below the measured number; the measured number falls inside the stated range.
By their numbers in this assay, from the lowest: compounds 1, 3 and 4 (each within the scatter of the next); then compound 2.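

In this assay, among the compounds shown here, replacing 2-methoxyphenyl with 4-methoxy-2-methylphenyl gives the first direct reading of a single change at this position, and the result is a number 5 percentage points higher from compound 3 to compound 4 (within the scatter), so the two compounds cannot be told apart. For this pair, then, the aromatic carbon next to the ring atom that bears the oxan-4-yl group accepts this change of the phenyl group without a shift in stability that stands clear of the usual variation between repeat measurements. Nothing available explains why this change leaves the reading so close.

A single pair cannot separate the addition of the methyl group from the different placement of the methoxy group, and it cannot show whether the same swap would give a similarly small step in a compound with other groups elsewhere on the shared core, such as compound 2. It also leaves open what a clearly different group on the phenyl ring, such as a nitrile or a carboxylic acid, or an amine in place of the phenyl ring, would do at this position.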